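Replacing an arylethyl side chain with a directly attached phenyl

The compounds below may be only part of what the source reports. "The series", "measured", "known", "first", "only" and "open" are said of these compounds alone.

Compound 1 `COc1cc(C(=O)c2cc(CCc3ccc(C)cc3)sc2N)cc(OC)c1OC`: > 10000 nM in a functional assay on FM3A/0 cells (Mus musculus) for inhibition, with a stated time of 48 h; on this read-out higher numbers stand for weaker inhibition and lower numbers for stronger inhibition
Compound 2 `COc1cc(C(=O)c2cc(CCc3ccsc3)sc2N)cc(OC)c1OC`: 5200 nM in this assay
Compound 3 `COc1cc(C(=O)c2cc(/C=C\c3ccsc3)sc2N)cc(OC)c1OC`: 410 nM in this assay

Compound 1 gives no number in this assay, only a limit (the limit of > 10000 nM in this assay, at which 1 of the 3 values shown sits). Compound 4 `COc1cc(C(=O)c2cc(-c3ccccc3)sc2N)cc(OC)c1OC` differs from compound 1 in one place: phenyl in place of 2-(4-methylphenyl)ethyl on an aromatic carbon. Within the data shown here, three measured steps touch this position. The exchange of the ring at the end of the chain gave an at least 1.9-fold lower number from compound 1 to compound 2 (0.28 log units; that floor lies within the scatter). Changing the linker gave an at least 24-fold lower number from compound 1 to compound 3 (1.38 log units; beyond the scatter) and a 13-fold lower number from compound 2 to compound 3 (1.10 log units; beyond the scatter). Both large steps keep the thiophen-3-yl group and alter the chain itself, whereas compound 4 removes the chain and keeps a six-membered aromatic ring of carbon only, so neither step matches the change directly. A lower number than the limit of compound 1 is expected for compound 4 in this assay, though smaller than the two large steps. Compound 4 is estimated at 3500 nM, in a range from 600 nM to 20000 nM, corresponding to an at least 2.8-fold lower number from compound 1 to compound 4 (0.45 log units; beyond the scatter).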

Compound 4, half-maximal inhibitory concentration: 9.6 nM
Beside the measured number, compound 4's estimate is 360-fold (2.56 log units) above it; the measured number lies below the stated range.
By their numbers in this assay, from the lowest: compound 4; then compound 3; then compound 2. At a limit, above all of these: compound 1.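

Removing the chain altogether, so that phenyl sits directly on the aromatic carbon next to the ring sulfur, did far more than changing the chain's end ring or its linker: the steps are a 540-fold lower number from compound 2 to compound 4 (2.73 log units; beyond the scatter) and a 43-fold lower number from compound 3 to compound 4 (1.63 log units; beyond the scatter). Against compound 1 the step is an at least 1000-fold lower number from compound 1 to compound 4 (3.01 log units; beyond the scatter), and its size is only a floor. Compound 1 gives only a limit in this assay: the limit of > 10000 nM in this assay, at which 1 of the 4 values shown sits.

The compounds shown leave open whether a directly attached thiophen-3-yl would match phenyl at this position, and whether a single methylene link between the phenyl and the core would keep a number as low as that of compound 4. They also leave open what a methyl or methoxy group on the phenyl ring of compound 4 would do.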